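Ester Swap on a Triterpenoid Diol Scaffold

The source may hold more compounds than are shown below. What is called first, only, known or untested is meant among the compounds shown, and "the series" means these compounds.

Measured so far in a functional assay on MDA-MB-231 cells (Homo sapiens) for antiproliferative activity, read by MTT assay, with a stated time of 72 h; on this read-out lower numbers stand for stronger inhibition and higher numbers for weaker inhibition:
- compound 1, `CC1=CCC2C(CC[C@@]2(C)O)C(C)(C)C1CC[C@@H]1[C@@]2(C)CC[C@@H](O)C(C)(C)O[C@@H]2CC[C@]1(C)O`, gives > 50000 nM, a limit of the assay rather than a number.
- compound 2, `CC1=CC[C@H]2[C@H](CC[C@]2(C)O)C(C)(C)[C@@H]1CC[C@H]1[C@]2(C)CC[C@H](OC(=O)CCC(=O)O)C(C)(C)O[C@H]2CC[C@@]1(C)O`, gives 27900 nM.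
- compound 3, `CC1=CC[C@H]2[C@H](CC[C@]2(C)O)C(C)(C)[C@@H]1CC[C@H]1[C@]2(C)CC/C(=N/OCc3ccccc3)C(C)(C)O[C@H]2CC[C@@]1(C)O`, gives 38200 nM.

Compound 2 holds the lowest of the two numbers obtained, but compound 3 sits within the usual scatter of it, so no order between the two can be claimed. Compound 1 is known only by the limit of > 50000 nM in this assay, at which 1 of the 3 values shown sits. Among the measured compounds shown here, all three share one core, and the measured compounds differ from each other in several places at once, so no single step between them can be isolated.

Compound 4, `COc1ccc(C(=O)O[C@H]2CC[C@]3(C)[C@H](CC[C@@](C)(O)[C@H]3CC[C@@H]3C(C)=CC[C@H]4[C@H](CC[C@]4(C)O)C3(C)C)OC2(C)C)cc1`, is the ester partner of compound 2. The change is 4-methoxyphenyl in place of 2-carboxyethyl on a carbonyl carbon.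

For the measured compounds named here, no measured step of this kind exists among the three compounds, so the expectation rests on the values themselves. Compound 2 and compound 3 both carry different groups at this same position of the core and both land in the same weak range, which suggests the position tolerates varied substituents without large swings. The step from compound 2 to compound 4 is expected to be a 1.7-fold lower number from compound 2 to compound 4 (0.24 log units; within the scatter), most likely toward a somewhat lower number but not clearly beyond the scatter. Compound 4 is therefore estimated at 16000 nM, within a range from 5000 nM to 45000 nM.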

Compound 4, half-maximal inhibitory concentration: 30600 nM
The estimate for compound 4 lay 1.9-fold (0.28 log units) below the measured number; the measured number falls inside the stated range.
By their numbers in this assay, from the lowest: compounds 2, 4 and 3 (each within the scatter of the next). At a limit, above all of these: compound 1.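

Among the compounds shown, this pair alone differs in one place, so it gives the first clean reading of this position: in this assay putting 4-methoxyphenyl in place of 2-carboxyethyl on a carbonyl carbon amounts to a 1.1-fold higher number from compound 2 to compound 4 (0.04 log units; within the scatter) and nothing more. On paper the change is not small: a chain with no ring and 1 hydrogen-bond donor leaves, and a six-membered aromatic ring of carbon only, with 0 hydrogen-bond donors, enters, yet the number stays within the usual scatter. For this one pair, then, neither that donor nor the presence of that aromatic ring decides the value, although a single pair cannot serve as a rule for the position.

On these data alone, whether any group on this carbonyl carbon can move the number beyond the scatter remains open, and a longer chain, an amine or a pyridine ring would each put that question to the test. Compound 1 stays a limit of the assay, and its steps to the other compounds cannot be read: the limit of > 50000 nM in this assay, at which 1 of the 4 values shown sits.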